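The source may hold more compounds than are shown below. What is called first, only, known or untested is meant among the compounds shown, and "the series" means these compounds.

Compound 2 `O=C(O)/C=C/c1ccncc1-c1ccc2ccccc2c1` stands highest of the three measured compounds in an assay on a protein complex for inhibition of CDK8/Cyclin C (Homo sapiens), with a stated time of 1 h, tested at 10 uM (a higher number here means more inhibition at the concentration tested (going by the name of the read-out), a lower number less inhibition), with 102%. Compound 1 `O=C(O)[C@@H]1CCCN1C(=O)/C=C/c1ccncc1-c1ccc2ccccc2c1` gives 67% in this assay, and compound 3 `CC(C)[C@@H](NC(=O)/C=C/c1ccncc1-c1ccc2ccccc2c1)C(=O)O` gives 77%. Compound 4 `CNC(=O)COc1ccncc1-c1ccc2ccccc2c1` has not yet been measured; it differs from compound 2 by (methylcarbamoyl)methoxy in place of 2-carboxyethenyl on an aromatic carbon. Among the measured compounds shown here, no measured step exchanges the whole 2-carboxyethenyl group. The nearest guides are the steps that replace the hydroxy on the carbonyl carbon, a number 35 percentage points higher from compound 1 to compound 2 (beyond the scatter) and a number 25 percentage points lower from compound 2 to compound 3 (beyond the scatter), which show that giving up that hydroxy costs inhibition. Compound 4 likewise gives up that hydroxy and also alters how the group is joined to the ring. A drop for compound 4 in this assay is therefore expected, a number 52 percentage points lower from compound 2 to compound 4 (beyond the scatter). Compound 4 is estimated at 50%, within a range from 20% to 85%.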

Compound 4, a percentage reported as inhibition, at one concentration (the size of the read-out at that concentration, not a potency): 4%
Compound 4: the middle estimate sits 46 percentage points above what was measured, and the stated range ends above it.
By their numbers in this assay, from the lowest: compound 4; then compounds 1 and 3 (each within the scatter of the next); then compound 2.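

At this position, opposite the ring nitrogen, replacing 2-carboxyethenyl with (methylcarbamoyl)methoxy gives a number 98 percentage points lower from compound 2 to compound 4 (beyond the scatter) in this assay and leaves almost no inhibition. Changing only the hydroxy on the carbonyl carbon cost less, with a number 25 percentage points lower from compound 2 to compound 3 (beyond the scatter) as the step, and compound 4 is the only compound shown without a carboxylic acid. Nothing available explains this fall.

The carboxylic acid and the ethenyl link change together here, so their shares remain unseparated. A carboxymethoxy group, or a methyl amide on the ethenyl chain, would separate them.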